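The source may hold more compounds than are shown below. What is called first, only, known or untested is meant among the compounds shown, and "the series" means these compounds.

Values measured in a functional assay on HCT-116 cells (Homo sapiens) for cytotoxicity, read by MTT assay, with a stated time of 48 h (a lower number here means a stronger inhibitor of growth, a higher number a weaker inhibitor of growth), follow

Compound 1 `OC[C@H]1O[C@@H](n2cnc3cc(F)c(F)cc32)[C@H](O)[C@@H]1O` gives 67000 nM
Compound 2 `Clc1cc2nc(-c3ccccc3Cl)[nH]c2cc1Cl` gives 23000 nM
Compound 3 `CCn1c(C(F)(F)F)nc2cc(Cl)c(Cl)cc21` gives 95300 nM

Compound 3, at 95300 nM, lies within the scatter of compound 1 and beyond the scatter of compound 2, on the side of weaker growth inhibition. Compound 4 `FC(F)(F)c1nc2cc(Cl)c(Cl)cc2n1C1CCCC1` has cyclopentyl in place of ethyl on an aromatic nitrogen and has not yet been measured. For the measured compounds named here, no two measured compounds differ in only one place, so the data offer no direct guide to this change. In this assay a modest move toward a lower number is expected, an estimated 1.7-fold lower number from compound 3 to compound 4 (0.24 log units; within the scatter) that may stay within the scatter. Compound 4 is expected at 55000 nM, with an estimated range from 20000 nM to 130000 nM.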

Compound 4, concentration for 50% growth inhibition: 22000 nM
Estimate against measurement, compound 4: 2.5-fold (0.40 log units) above; the measured number falls inside the stated range.
By their numbers in this assay, from the lowest: compounds 4 and 2 (each within the scatter of the next); then compounds 1 and 3 (each within the scatter of the next).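

In this assay, for the compounds shown here, the aromatic nitrogen next to the ring atom bearing trifluoromethyl proves sensitive to what it carries: cyclopentyl in place of ethyl gives a 4.3-fold lower number from compound 3 to compound 4 (0.64 log units; beyond the scatter), the first single-place comparison in this set. This one pair links the larger carbon-only ring at this position with stronger growth inhibition. No measured evidence here explains the step. On these data alone, whether the ring itself or simply more carbon matters stays open; a butyl chain or a cyclohexyl group on this nitrogen would separate the two.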